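This account rests on a few compounds, and the source may have more. Where it says the series, first, only, none or still open, it means among the compounds named here.

Measured so far:
- compound 1 `CCOC(=O)c1c(C)nc(-c2cccc(C#N)c2)n1OCCC(=O)O`: > 30000 nM
- compound 2 `CCOC(=O)c1c(C)nc(-c2cccc(C#N)c2)n1OCc1cccc(Cl)c1`: 19400 nM

In a functional assay on a cell-free system (plasma, Oryctolagus cuniculus) for inhibition, with stated times of 5 min, 1 min and 6 min (on this read-out lower numbers stand for stronger inhibition and higher numbers for weaker inhibition), compound 1 gives > 30000 nM, which is a limit of the assay and not a number (the limit of > 30000 nM in this assay, at which 1 of the 2 values shown sits). Compound 2 gives 19400 nM, the only number shown in this assay. Going by the values given here, the one measured step is an at least 1.5-fold lower number from compound 1 to compound 2 (0.18 log units; that floor lies within the scatter). Compound 3 `CCOC(=O)c1c(C)nc(-c2cccc(C#N)c2)n1OCc1ccc(C(=O)OC)cc1` is not yet measured; it differs from compound 2 as follows: 4-(methoxycarbonyl)phenyl in place of 3-chlorophenyl on a saturated chain carbon bound to an oxygen on an aromatic ring. Among the compounds with values here, no measured step exchanges one aryl group for another on a saturated chain carbon bound to an oxygen on an aromatic ring, so in this assay a step of no size beyond the usual scatter is expected. For compound 3 the expected value is 20000 nM (range 7000 nM to 60000 nM). This estimate means an expected step of a 1.0-fold higher number from compound 2 to compound 3 (0.01 log units; within the scatter).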

Compound 3, half-maximal inhibitory concentration: 9470 nM
The estimate for compound 3 lay 2.1-fold (0.32 log units) above the measured number; the measured number falls inside the stated range.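

In this assay, 4-(methoxycarbonyl)phenyl in place of 3-chlorophenyl gives a 2.0-fold lower number from compound 2 to compound 3 (0.31 log units; beyond the scatter), so the choice of aryl group on the saturated chain carbon bound to an oxygen on an aromatic ring can move the number beyond the scatter. Against carboxymethyl, the same aryl group gives an at least 3.1-fold lower number from compound 1 to compound 3 (0.50 log units; beyond the scatter), whereas the floor of the 3-chlorophenyl step stayed within the scatter. Compound 1 stands at a limit and not a number: the limit of > 30000 nM in this assay, at which 1 of the 3 values shown sits.

From the compounds shown here alone, the two aryl groups differ in both substituent and ring location, so which of these carries the step stays open. A 4-chlorophenyl or 4-carboxyphenyl group would help separate them.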